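Swapping the cinnamamide aryl group in a trimethoxybenzophenone series

A few compounds are considered here, and "the series" means these few. Any claim that something is new, unique, unknown or untested is made for them only; others in the source may bear on it.

Measured compounds:
compound 1 `C#CCOc1cccc(/C=C/C(=O)Nc2cc(C(=O)c3cc(OC)c(OC)c(OC)c3)ccc2OC)c1`, 13400 nM
compound 2 `COc1cc(C(=O)c2cc(OC)c(OC)c(OC)c2)cc(NC(=O)/C=C/c2cc(OC)c(OC)c(OC)c2)c1OC`, 5300 nM
compound 3 `C#CCOc1cccc(/C=C/C(=O)Nc2cc(C(=O)c3cc(OC)c(OC)c(OC)c3)cc(OC)c2OC)c1`, 11200 nM

All three were tested in a functional assay on COLO 205 cells (Homo sapiens) for cytotoxicity, read by MTT assay, with a stated time of 72 h; on this read-out lower numbers stand for stronger inhibition and higher numbers for weaker inhibition. Compound 3 gives 11200 nM, the second highest of the three numbers. Its nearest neighbour is compound 1, and the step of a 1.2-fold lower number from compound 1 to compound 3 (0.08 log units; within the scatter) shows that adding a methoxy on an aromatic carbon changed nothing that can be trusted. Its furthest neighbour is compound 2, and the step of a 2.1-fold higher number from compound 2 to compound 3 (0.32 log units; beyond the scatter) shows that replacing 3,4,5-trimethoxyphenyl with 3-(propargyloxy)phenyl on the double-bonded chain carbon cost a modest amount.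

Compound 4 `COc1cc(C(=O)c2cc(OC)c(OC)c(OC)c2)cc(NC(=O)/C=C/c2cc(F)c(F)c(F)c2)c1OC` has not yet been measured. It differs from compound 3 in one place: 3,4,5-trifluorophenyl in place of 3-(propargyloxy)phenyl on a double-bonded chain carbon bound to a double-bonded chain carbon. Among the compounds with values here, the only measured step at that position is the one from compound 2 to compound 3, and it was modest in size. Within the data shown here, nothing measured here speaks to a trifluorophenyl group at this place, so there is no direct guide to direction; the change at the same position is the only precedent, and its size sets the expected magnitude. Compound 4 is therefore expected to land near compound 3, with the step of a 1.1-fold lower number from compound 3 to compound 4 (0.05 log units; within the scatter) estimated as small. The estimate for compound 4 in this assay is 10000 nM, with a range from 3000 nM to 35000 nM.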

Compound 4, half-maximal inhibitory concentration: 4300 nM
Compound 4: middle estimate off by 2.3-fold (0.37 log units), on the high side; measured number inside the range.
By their numbers in this assay, from the lowest: compounds 4 and 2 (each within the scatter of the next); then compounds 3 and 1 (each within the scatter of the next).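

In this assay, the change at this position now has a measured effect in the favourable direction: a 2.6-fold lower number from compound 3 to compound 4 (0.42 log units; beyond the scatter) shows that 3,4,5-trifluorophenyl gives a modestly lower number than 3-(propargyloxy)phenyl on the same core. The earlier compounds shown here offered only 3,4,5-trimethoxyphenyl as a comparison for 3-(propargyloxy)phenyl, and a 1.2-fold lower number from compound 2 to compound 4 (0.09 log units; within the scatter) shows that the trifluorophenyl and trimethoxyphenyl groups cannot be told apart here, although their substituents are of entirely different kinds, so on this core the two groups stand level and 3-(propargyloxy)phenyl alone gives the higher number. No measurement shown here explains why these two groups read alike or why 3-(propargyloxy)phenyl differs from them.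

On these data alone, it remains open whether a plain phenyl, a phenyl carrying a single fluorine, or a phenyl carrying a single methoxy would read like these two groups, which would show whether all three substituents are needed at this position. As far as these compounds go, it is equally open how a phenyl bearing an amine or a carboxylic acid, or a longer chain in place of the propargyloxy group, would behave on this core.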